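The source may report more compounds than this note shows. Statements on the series, on what has been measured and on what is new or still open speak of the compounds shown alone.

Compound 1 `O=C1Nc2c(C(F)(F)F)cccc2[C@@]1(c1ccc(O)cc1)C1CCC(F)(F)CC1`: > 1000 nM (a limit)
Compound 2 `O=C1Nc2c(C(F)(F)F)cccc2C1(c1ccc(OC(F)(F)F)cc1)c1ccc(O)cc1F`: 177 nM

Among the measured compounds shown here, only two compounds have been tested so far, both in a functional assay on MCF7 cells (Homo sapiens) for inhibition, read by resazurin assay, with a stated time of 24 h; a higher number here means a weaker inhibitor, a lower number a stronger inhibitor. Compound 1 is reported as > 1000 nM, which is a limit of the assay and not a number. For the measured compounds named here, compound 2 gives 177 nM, the only actual number available, so it serves as the single anchor for what follows.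

The next compound, compound 3 `Cc1cc(C2(c3ccc(OC(F)(F)F)cc3)C(=O)Nc3c(C(F)(F)F)cccc32)ccc1O`, keeps the core of compound 2 and alters one group. It has 4-hydroxy-3-methylphenyl in place of 2-fluoro-4-hydroxyphenyl on a saturated ring carbon. Going by the values given here, no measured step shows what a change of this kind does in this assay, so there is no direct precedent. The two groups differ only in exchanging the fluorine for a methyl group, and both keep the hydroxy group. For that reason, no shift beyond the scatter is expected, in either direction, from the level of compound 2 at 177 nM. The expected change is small: a 1.1-fold higher number from compound 2 to compound 3 (0.05 log units; within the scatter). For compound 3 the estimated value is 200 nM, with an expected range from 70 nM to 600 nM.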

Compound 3, half-maximal inhibitory concentration: > 1000 nM
Compound 3: only a limit was reported; the forecaster's own chance of this, stated with the estimate: 8%; at least 5.0-fold (0.69 log units) between middle value and limit.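

In this assay, replacing 2-fluoro-4-hydroxyphenyl with 4-hydroxy-3-methylphenyl on the saturated ring carbon gives an at least 5.6-fold higher number from compound 2 to compound 3 (0.75 log units; beyond the scatter), so a small exchange at this position can matter even when the hydroxy group stays in the entering group. Among the compounds shown here, the earlier pair could not show this, since compound 1 and compound 2 differ in more than one place, whereas here only one group changes and the fluorine gives way to a methyl group. The step can only be read as a minimum, because compound 3 is reported only as a limit of the assay and not as a number: the limit of > 1000 nM in this assay, at which 2 of the 3 values shown sit.

The compounds shown do not separate the effect of removing the fluorine from that of adding the methyl group, and the actual number for compound 3 stays unknown. Also open, from the compounds shown here alone, is how the same aromatic ring would behave with a chlorine atom, a methoxy group or an amine in place of the methyl group, and whether any such group would keep the level of compound 2 at 177 nM.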